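The source may hold more compounds than are shown below. What is called first, only, known or untested is meant among the compounds shown, and "the series" means these compounds.

Compound 3 `COc1cc(OC)c2c(=O)cc(C(=O)Nc3ccc(Oc4ccc(F)cc4)cc3)[nH]c2c1` is the weakest-looking member of a small set of amides sharing one core. Compound 1 `COc1cc(OC)c2c(=O)cc(C(=O)Nc3ccc(C4CCCCC4)cc3)[nH]c2c1` gives 18400 nM in a functional assay on KOPN-8 cells (Homo sapiens) for antiproliferative activity, with a stated time of 72 h (a lower number here means that less compound is needed, a higher number that more compound is needed for the effect), and compound 2 `COc1cc(OC)c2c(=O)cc(C(=O)Nc3ccc(Oc4ccc([N+](=O)[O-])cc4)cc3)[nH]c2c1` gives 20500 nM in this assay; the two sit within the scatter of each other, as the step of a 1.1-fold higher number from compound 1 to compound 2 (0.05 log units; within the scatter) shows. Compound 3, by contrast, reaches only the assay limit, > 50000 nM, a boundary rather than a measured number. The steps of an at least 2.7-fold higher number from compound 1 to compound 3 (0.43 log units; beyond the scatter) and an at least 2.4-fold higher number from compound 2 to compound 3 (0.38 log units; beyond the scatter) both point the same way, so compound 3 stands at the bottom of what has been measured, on the limit line (the limit of > 50000 nM in this assay, at which 1 of the 3 values shown sits).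

Compound 4 `COc1cc(OC)c2c(=O)cc(C(=O)Nc3ccc(Oc4cccnc4)cc3)[nH]c2c1` differs from compound 3 in one place: pyridin-3-yl in place of 4-fluorophenyl on an oxygen on an aromatic ring. Going by the values given here, no measured step swaps the outer ring itself; the step from compound 2 to compound 3 only changes a substituent on that ring, and the step from compound 1 to compound 3 replaces cyclohexyl wholesale. The expectation for compound 4 is therefore loosely anchored, with a guessed step of an at least 1.6-fold lower number from compound 3 to compound 4 (0.22 log units; that floor lies within the scatter) in this assay. Compound 4 is estimated at 30000 nM, within 8000 nM to 100000 nM.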

Compound 4, half-maximal effective concentration: > 32100 nM
Compound 4: no number, only a limit; the forecaster's own chance of this, stated with the estimate: 45%; at least 1.0-fold (0.02 log units) between middle value and limit.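

In this assay compound 4 gives only a limit, > 32100 nM, and not a number. At this place on the oxygen, pyridin-3-yl therefore gives no measured value, as 4-fluorophenyl in compound 3 gives none, while the steps of an at least 1.5-fold higher number from compound 2 to compound 4 (0.19 log units; that floor lies within the scatter) and an at least 1.7-fold higher number from compound 1 to compound 4 (0.24 log units; that floor lies within the scatter) both have floors within the scatter, so neither shows that compound 4 truly needs more compound than the two with measured numbers. The step between compound 3 and compound 4 cannot be read, because each of the two has only a limit: the limit of > 32100 nM in this assay, at which 1 of the 4 values shown sits.

From the compounds shown here alone, how far apart compound 3 and compound 4 really lie stays open. The compounds shown also leave open what an amine or a carboxylic acid on the outer ring would give in this assay.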